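Cyclopentyl for Cyclohexyl on the Acyl Carbonyl

The source may report more compounds than this note shows. Statements on the series, on what has been measured and on what is new or still open speak of the compounds shown alone.

Compound 1 `O=C(C1CCCCC1)N1N=CCC1c1ccccc1`: 0.617 h
Compound 2 `CC(C)(C)C(=O)N1N=CCC1c1cccnc1`: > 1.5 h

In an ADME assay on microsomes (Homo sapiens) for metabolic stability (a lower number here means that the compound disappears faster, a higher number that the compound lasts longer), compound 1 gives 0.617 h, the only plain number among the two results shown. Compound 2 in this assay reaches > 1.5 h, which is a limit of the assay and not a number. That result sits at the limit of > 1.5 h in this assay, at which 1 of the 2 values shown sits. Compound 3 `O=C(C1CCCC1)N1N=CCC1c1ccccc1` has not yet been measured in this assay. It differs from compound 1 in one place: cyclopentyl in place of cyclohexyl on a carbonyl carbon. Within the data shown here, no pair of measured compounds separated by a single change is available here, so the size of such a step cannot be read from these data. The expected step from compound 1 to compound 3 in this assay is a 1.2-fold higher number from compound 1 to compound 3 (0.08 log units; within the scatter), a change estimated to stay within the usual scatter. Compound 3 is accordingly expected to give 0.75 h, with a range from 0.35 h to 1.6 h.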

Compound 3, half-life: 1.13 h
Estimate against measurement, compound 3: 1.5-fold (0.18 log units) below; the measured number falls inside the stated range.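

Cyclopentyl in place of cyclohexyl on a carbonyl carbon gives the first step that can be read at this place in this assay, a 1.8-fold higher number from compound 1 to compound 3 (0.26 log units; within the scatter) and so this swap of a six-membered for a five-membered carbon ring stays inside what repeated measurements would show. Compound 3 gives a plain number, as compound 1 does, so both ends of this step can be read. Compound 2 remains a limit of the assay and not a number: the limit of > 1.5 h in this assay, at which 1 of the 3 values shown sits.

Compound 2 differs from compound 1 and from compound 3 in more than one place, so steps to it cannot be read. Going by these compounds, whether another group on this carbonyl, such as a longer open chain or a ring carrying an amine, would move the half-life beyond the scatter stays open.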